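The source may report more compounds than this note shows. Statements on the series, on what has been measured and on what is new or still open speak of the compounds shown alone.

Within the data shown here, compound 3 `CC(C)(c1cccnc1)C(O)c1ccccc1` is examined in a functional assay for inhibition of cytochrome P450 11B1, mitochondrial (Bos taurus) (on this read-out lower numbers stand for stronger inhibition and higher numbers for weaker inhibition), where compound 3 gives 1530 nM, the lowest of the three numbers measured so far. Its nearest neighbour is compound 1 `CC(C)(Cc1cccnc1)c1cccnc1`, for which compound 1 gives 2640 nM, a gap that sits within the scatter; the furthest is compound 2 `COC(c1cccnc1)C(C)(C)c1cccnc1`, for which compound 2 gives 7300 nM, a gap beyond the scatter. Among the measured compounds shown here, the only single-place step among the measured compounds is a 2.8-fold higher number from compound 1 to compound 2 (0.44 log units; beyond the scatter), a modest weakening when methoxy replaces hydrogen on the saturated chain carbon bound to an aromatic carbon and a saturated chain carbon. Compound 4 `CC(C)(c1cccnc1)C(Cl)c1ccccc1` differs from compound 3 in one place: chloro in place of hydroxy on a saturated chain carbon bound to an aromatic carbon and a saturated chain carbon. For the measured compounds named here, that step touches the same carbon as the methoxy step, but swaps a different pair of groups, so no measured step reports on it directly, and the methoxy step itself stayed modest. The expectation for this assay is therefore a step of about a 1.2-fold higher number from compound 3 to compound 4 (0.07 log units; within the scatter), not clearly beyond the scatter. Compound 4 is accordingly estimated at 1800 nM, with a range from 600 nM to 5400 nM.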

Compound 4, half-maximal inhibitory concentration: 1630 nM
Beside the measured number, compound 4's estimate is 1.1-fold (0.04 log units) above it; the measured number falls inside the stated range.
By their numbers in this assay, from the lowest: compounds 3, 4 and 1 (each within the scatter of the next); then compound 2.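

In this assay, chloro in place of hydroxy on this saturated chain carbon gives a 1.1-fold higher number from compound 3 to compound 4 (0.03 log units; within the scatter), so this read-out does not separate the two groups. Hydroxy, with its hydrogen-bond donor and acceptor, can therefore give way at this carbon to chloro, which counts neither, without a step beyond the scatter, whereas the only earlier step at such a carbon, the methoxy change, gave a 2.8-fold higher number from compound 1 to compound 2 (0.44 log units; beyond the scatter) in another pair of compounds. No measured evidence accounts for this result.

The compounds shown leave open whether an amine, a fluoro group or a longer chain on this carbon would also stay within the scatter of compound 3. They also leave open whether the chloro result would hold on the core of compound 1.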